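The compounds below may be only part of what the source reports. "The series", "measured", "known", "first", "only" and "open" are said of these compounds alone.

Three compounds have been measured in an ADME assay on BV-2 cells (Mus musculus) for cytotoxicity, with a stated time of 24 h, tested at 10 uM; a lower number here means a stronger effect, a higher number a weaker effect of the compound at the concentration tested:

Compound 1, `COc1ccccc1S(=O)(=O)/C=C/c1ccccn1`, gives 100%.
Compound 2, `COc1ccccc1S(=O)(=O)/C=C/c1ncccc1F`, gives 100%.
Compound 3, `COc1ccc(S(=O)(=O)/C=C/c2cccnc2)cc1`, gives 99.5%.

Compound 2 is derived from compound 1 by fluoro in place of hydrogen on an aromatic carbon, and this step gave no change at the digits printed from compound 1 to compound 2 (within the scatter). Compound 3 shares its atoms with compound 1 but joins them differently; the difference between the two cores is not broken down here. The value of compound 3 in this assay lies within the scatter of both compound 1 and compound 2, so no order among the three can be read from these numbers.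

Compound 4, `COc1ccc(S(=O)(=O)/C=C/c2ccc(F)nc2)cc1`, has not yet been measured. It differs from compound 3 by fluoro in place of hydrogen on an aromatic carbon, which is the same kind of change as that from compound 1 to compound 2, but the place differs: in compound 4 the fluoro sits next to the ring nitrogen and para to a large group, whereas in compound 2 it sits ortho to a large group and two atoms from the ring nitrogen. Since the earlier step gave no change at the digits printed from compound 1 to compound 2 (within the scatter), the step to compound 4 is expected to be a number 0.5 percentage points lower from compound 3 to compound 4 (within the scatter). Compound 4 is therefore estimated to give 99% in this assay, with a likely range from 90% to 101%.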

Compound 4, a percentage reported as activity, at one concentration (the size of the read-out at that concentration, not a potency): 100%
For compound 4 the middle estimate is 1 percentage points below the measured one; the measured number falls inside the stated range.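

In this assay, fluoro in place of hydrogen on an aromatic carbon gave a number 0.5 percentage points higher from compound 3 to compound 4 (within the scatter). Set beside the earlier step, the change reads alike on the two cores: the same change on two cores in this assay, no change at the digits printed (within the scatter) from compound 1 to compound 2 and a number 0.5 percentage points higher (within the scatter) from compound 3 to compound 4, 0.5 percentage points apart, within the scatter of two such steps. So in these two pairs the change carried from one core to the other with no step beyond the scatter, but this rests on only two cores, with the fluoro in a different place on each, and on a read-out at one concentration, so it shows neither a rule for the whole series nor anything about potency.

The compounds shown leave open whether a group other than fluoro on the same aromatic carbon, such as chloro, methyl or an amine, would also leave the number in this assay within the scatter. They also leave open what would follow if the methoxy group gave way to a hydroxyl or a longer alkoxy chain.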